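The compounds below may be only part of what the source reports. "The series", "measured", "known", "first", "only" and "open" are said of these compounds alone.

Measured so far in an assay for inhibition of prostacyclin synthase (Homo sapiens), using microsomes; on this read-out lower numbers stand for stronger inhibition and higher numbers for weaker inhibition:
compound 1 `CC(C)(Oc1ccc(F)cc1)C1OCC(C/C=C\CCC(=O)O)C(c2cccnc2)O1` gives 2000 nM
compound 2 `CC(C)(Oc1ccccc1[N+](=O)[O-])C1OCC(C/C=C\CCC(=O)O)C(c2cccnc2)O1` gives < 1000 nM, which is a limit of the assay the limit of < 1000 nM in this assay, at which 1 of the 2 values shown sits.

Within the data shown here, compound 2 therefore stands only as a limit in this assay; the single measured step, an at least 2.0-fold lower number from compound 1 to compound 2 (0.30 log units; that floor lies within the scatter), reaches it, and its floor sits within the scatter. Compound 3 `CC(C)(Cc1ccccc1)C1OCC(C/C=C\CCC(=O)O)C(c2cccnc2)O1` differs from compound 2 by benzyl in place of 2-nitrophenoxy on a saturated chain carbon bound to two saturated chain carbons and a saturated ring carbon. Among the measured compounds shown here, no measured step covers this kind of change; the step from compound 1 to compound 2 exchanged one aryl for another on the oxygen, which is kept in both. Any expectation for the direction of the move in this assay rests on that one step alone and is weak. In this assay compound 3 is expected near 1500 nM, within 300 nM to 8000 nM. The estimated step is an at least 1.5-fold higher number from compound 2 to compound 3 (0.17 log units; that floor lies within the scatter), not one claimed to lie beyond the scatter.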

Compound 3, half-maximal inhibitory concentration: 13000 nM
Beside the measured number, compound 3's estimate is 8.7-fold (0.94 log units) below it; the measured number lies above the stated range.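

Among these compounds, at this saturated chain carbon, the earlier compounds varied only the aryl group on the oxygen, whereas benzyl in place of 2-nitrophenoxy gives an at least 13-fold higher number from compound 2 to compound 3 (1.11 log units; beyond the scatter) in this assay. Benzyl in place of 4-fluorophenoxy gives a 6.5-fold higher number from compound 1 to compound 3 (0.81 log units; beyond the scatter), so compound 3 lies beyond the scatter from both phenoxy compounds. The first of these steps is a floor only: the limit of < 1000 nM in this assay, at which 1 of the 3 values shown sits.

Still open, as far as these compounds go, is whether the loss goes with the absent oxygen or with the absent ring substituents, as both differ in compound 3. From the compounds shown here alone, how an unsubstituted phenoxy group or an amine in place of the oxygen would read here also remains open.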